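Permeability notes on the aminoquinoline series: compound 4 outlook

This account rests on a few compounds, and the source may have more. Where it says the series, first, only, none or still open, it means among the compounds named here.

Measured so far, in an ADME assay for permeability, using PAMPA, with a stated time of 30 min, at pH 7.4; a lower number here means that the compound crosses the layer more slowly, a higher number that the compound crosses the layer faster:
compound 1 `COc1cccc(Oc2ccc3c(NCCCNCc4cccc(OC)c4O)ccnc3c2)c1`, 317 10^-6 cm/s
compound 2 `COc1cccc(CNCCCNc2ccnc3cc(Cc4cccc(C(F)(F)F)c4)ccc23)c1O`, 23 10^-6 cm/s
compound 3 `COc1ccc(Oc2ccc3c(NCCCNCc4cccc(OC)c4O)ccnc3c2)cc1`, 317 10^-6 cm/s

Compound 3 stands level with compound 1 in this assay, the two together at the top of the three numbers; no change at the digits printed from compound 1 to compound 3 (within the scatter). Compound 2 sits well apart: a 14-fold higher number from compound 2 to compound 3 (1.14 log units; beyond the scatter), and likewise a 14-fold lower number from compound 1 to compound 2 (1.14 log units; beyond the scatter).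

Compound 4 `COc1cccc(CNCCCNc2ccnc3cc(-c4ccc(C(F)(F)F)cc4)ccc23)c1O` differs from compound 3 as follows: 4-(trifluoromethyl)phenyl in place of 4-methoxyphenoxy on an aromatic carbon. Going by the values given here, the only measured steps that bear on it are those in which a trifluoromethyl-bearing aryl group stands in for a methoxyphenoxy group, and both were large, with the trifluoromethyl-bearing compound the lower. Among the compounds with values here, a step of roughly that size and direction is therefore expected here, an 11-fold lower number from compound 3 to compound 4 (1.02 log units; beyond the scatter), with the caveat that no measured pair covers a directly attached phenyl. Compound 4 is estimated at 30 10^-6 cm/s, range 10 10^-6 cm/s to 100 10^-6 cm/s.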

Compound 4, apparent permeability: 237 10^-6 cm/s
The estimate for compound 4 lay 7.9-fold (0.90 log units) below the measured number; measured number outside the range, above it.
By their numbers in this assay, from the lowest: compound 2; then compounds 4, 1 and 3 (each within the scatter of the next).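

In this assay, a trifluoromethyl-bearing aryl group on this aromatic carbon does not by itself go with a low number: 4-(trifluoromethyl)phenyl in place of either methoxyphenoxy group stays within the scatter, a 1.3-fold lower number from compound 3 to compound 4 (0.13 log units; within the scatter) and a 1.3-fold lower number from compound 1 to compound 4 (0.13 log units; within the scatter). The one large step among these new comparisons sets 4-(trifluoromethyl)phenyl against 3-(trifluoromethyl)benzyl, a 10-fold higher number from compound 2 to compound 4 (1.01 log units; beyond the scatter), so the low number stands with compound 2 alone. No supporting data bear on the reason for this result.

With compound 2 the only benzyl example, the compounds shown leave open whether the low number follows the benzyl group or the place of its trifluoromethyl group. From the compounds shown here alone, how an amine or a carboxylic acid on this aromatic carbon would read also remains open.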